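Enol ether in place of the dimethylaminoethyl chain

This account rests on a few compounds, and the source may have more. Where it says the series, first, only, none or still open, it means among the compounds named here.

Measured so far:
compound 1, `COc1cc(OC)cc(C(=CCCN(C)C)c2ccc(OC)c(OC)c2)c1`, > 10000 nM in a functional assay on HCT-116 cells (Homo sapiens) for cytotoxicity, read by scintillation counting and thymidine incorporation, with a stated time of 72 h; a lower number here means a stronger inhibitor, a higher number a weaker inhibitor
compound 2, `CCOc1cc(C(=CC#N)c2cc(OC)cc(OC)c2)ccc1OC`, 34 nM

Compound 1 gives only a limit in this assay, (the limit of > 10000 nM in this assay, at which 1 of the 2 values shown sits). For the measured compounds named here, compound 2, which carries a nitrile on the double-bonded chain, is the one measured compound with a number, at 34 nM. Compound 3, `COC=C(c1cc(OC)cc(OC)c1)c1ccc(OC)c(OC)c1`, keeps the core of compound 1 and changes one place: methoxy in place of 2-(dimethylamino)ethyl on a double-bonded chain carbon bound to a double-bonded chain carbon. Going by the values given here, no measured pair differs in a single place, so the size of this step is not known from the data. The step from compound 1 to compound 3 is expected to move toward stronger inhibition, beyond the usual scatter, though compound 1 sits at a limit and the true gap cannot be read. The estimated step is an at least 5.0-fold lower number from compound 1 to compound 3 (0.69 log units; beyond the scatter). Compound 3 is expected at 2000 nM, between 200 nM and 15000 nM.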

Compound 3, half-maximal inhibitory concentration: > 10000 nM
Compound 3 was reported as a limit (the forecaster's own chance of this, stated with the estimate: 30%); middle value at least 5.0-fold (0.69 log units) from the limit.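

Compound 1 and compound 3 both stand at a limit in this assay, so no step between them can be read: the limit of > 10000 nM in this assay, at which 2 of the 3 values shown sit.

The compounds shown leave open how strongly either of the two inhibits, and whether methoxy in place of 2-(dimethylamino)ethyl changes the inhibition at all.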